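The source may report more compounds than this note shows. Statements on the series, on what has been measured and on what is new or still open speak of the compounds shown alone.

Measured in an in vitro assay on SH-EP1 cells for displacement of a labelled ligand from Neuronal acetylcholine receptor; alpha4/beta2 (Homo sapiens); on this read-out lower numbers stand for stronger inhibition and higher numbers for weaker inhibition:
compound 1 `COc1cncc(C2=CC3CC(C2)CN(C)C3)c1`, 0.6 nM
compound 2 `Clc1cncc(C2=CC3CNCC(C2)C3)c1`, 0.4 nM

Compound 2 has the lower of the two numbers, and compound 1 sits within the scatter of it, so the two cannot be told apart. The next compound, compound 3 `COc1cncc(C2=CC3CNCC(C2)C3)c1`, keeps the core of compound 2 and carries methoxy in place of chloro on an aromatic carbon. For the measured compounds named here, no pair of measured compounds shows this change on its own, so there is no step to lean on. Compound 1 carries the same methoxy group and gives a number close to compound 2, which suggests the change from compound 2 to compound 3 is expected to be small, with no shift beyond the scatter: a 1.3-fold higher number from compound 2 to compound 3 (0.10 log units; within the scatter). Compound 3 is therefore estimated at 0.5 nM in this assay, with a range from 0.2 nM to 1.3 nM.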

Compound 3, inhibition constant: 0.3 nM
Beside the measured number, compound 3's estimate is 1.7-fold (0.22 log units) above it; the measured number falls inside the stated range.
By their numbers in this assay, from the lowest: compounds 3, 2 and 1 (each within the scatter of the next).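

In this assay, methoxy in place of chloro on an aromatic carbon two atoms from the ring nitrogen can now be read directly as a 1.3-fold lower number from compound 2 to compound 3 (0.12 log units; within the scatter) on the shared core, so this position holds either group with no shift beyond the scatter. Hydrogen in place of methyl on the amine nitrogen in a ring gives a 2.0-fold lower number from compound 1 to compound 3 (0.30 log units; within the scatter) and also stays within the scatter. Nothing on hand accounts for either step. As far as these compounds go, whether an amine or ethoxy at this aromatic carbon, or ethyl on the ring nitrogen, would stay within the scatter remains open.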